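The source may hold more compounds than are shown below. What is called first, only, known or untested is meant among the compounds shown, and "the series" means these compounds.

Compound 1 `Cn1cc(SCc2nnc(SCc3ccccc3Cl)n2-c2c(Cl)cccc2Cl)c2ccccc21` is the starting point. In a toxicity assay on HEK-293T cells (Homo sapiens) for cytotoxicity, read by CCK-8 assay, with a stated time of 48 h (a lower number here means that less compound is tolerated, a higher number that more compound is tolerated), compound 1 gives 49600 nM, one of two plain numbers in hand and close to its neighbour. Compound 2 `Cn1cc(SCc2nnc(SCc3cc(C(F)(F)F)ccc3Cl)n2-c2c(Cl)cccc2Cl)c2ccccc21` gives 53800 nM in this assay, and a 1.1-fold higher number from compound 1 to compound 2 (0.04 log units; within the scatter). Compound 3 `Cn1cc(SCc2nnc(SCc3c(Cl)cccc3Cl)n2-c2c(Cl)cccc2Cl)c2ccccc21` in this assay reaches only a limit of the assay, > 100000 nM. Accordingly, an at least 2.0-fold higher number from compound 1 to compound 3 (0.30 log units; that floor lies within the scatter). Compound 4 `Cn1cc(SCc2nnc(SCc3cccc(Cl)c3F)n2-c2c(Cl)cccc2Cl)c2ccccc21` is not yet measured; compared with compound 1, (3-chloro-2-fluorophenyl in place of 2-chlorophenyl on a saturated chain carbon bound to a sulfur). Both measured steps from compound 1, the trifluoromethyl one to compound 2 and the chloro one to compound 3, stayed within the scatter, so compound 4 is expected to sit near compound 1, with a 1.2-fold higher number from compound 1 to compound 4 (0.08 log units; within the scatter). The estimate for compound 4 in this assay is 60000 nM, between 30000 nM and 120000 nM.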

Compound 4, half-maximal cytotoxic concentration: > 100000 nM
Compound 4 ended at the assay's limit; the forecaster's own chance of this, stated with the estimate: 25%; middle value at least 1.6-fold (0.22 log units) away from the limit.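

Placing 3-chloro-2-fluorophenyl on the saturated chain carbon bound to a sulfur gives an at least 2.0-fold higher number from compound 1 to compound 4 (0.30 log units; that floor lies within the scatter), and an at least 1.8-fold higher number from compound 2 to compound 4 (0.26 log units; that floor lies within the scatter), so neither step is shown to be a real rise. Compound 4 is the second compound to end at a limit in this assay: the limit of > 100000 nM in this assay, at which 2 of the 4 values shown sit. The step between compound 3 and compound 4 cannot be read, as both values are limits. On this ring, the compounds shown carry only chloro, fluoro and trifluoromethyl groups. On these data alone, whether an amine or a carboxylic acid there would also reach the limit remains open.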